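Chain lengthening on a shared core in PC-3 cells

The source may report more compounds than this note shows. Statements on the series, on what has been measured and on what is new or still open speak of the compounds shown alone.

The series rests on one shared core, carried by compound 1 `CCc1cc2ccccc2nc1-c1cc(-c2ccccc2)no1`, compound 2 `CCCc1cc2ccccc2nc1-c1cc(-c2ccccc2)no1` and compound 3 `CCCCc1cc2ccccc2nc1-c1cc(-c2ccc(C(F)(F)F)cc2)no1`. In a functional assay on PC-3 cells (Homo sapiens) for inhibition, read by MTT assay, with a stated time of 24 h (a lower number here means a stronger inhibitor, a higher number a weaker inhibitor), compound 1 gives only a limit, > 100000 nM, which is the limit of > 100000 nM in this assay, at which 1 of the 3 values shown sits. In this assay compound 2 gives 51300 nM, and compound 3 gives 10800 nM. The change from compound 1 to compound 2 is methyl in place of hydrogen on a saturated chain carbon, two bonds along the chain from an aromatic carbon, and it brings an at least 1.9-fold lower number from compound 1 to compound 2 (0.28 log units; that floor lies within the scatter). The difference between the cores of compound 1 and compound 3 is not broken down here; their two values show the lower number for compound 3.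

Compound 4 `CCCCCc1cc2ccccc2nc1-c1cc(-c2ccc(C(F)(F)F)cc2)no1` has not yet been measured in this assay. It differs from compound 3 by methyl in place of hydrogen on a saturated chain carbon, four bonds along the chain from an aromatic carbon. This is the same kind of change as that from compound 1 to compound 2, but not the same: there the methyl enters two bonds along the chain from an aromatic carbon, here four bonds along the chain from an aromatic carbon. He expects, beside the earlier step, a modest step of a 1.8-fold lower number from compound 3 to compound 4 (0.26 log units; within the scatter), resting on compound 2 with 51300 nM and compound 3 with 10800 nM, where each extra chain carbon so far came with a lower number. His estimate for compound 4 in this assay is 6000 nM, between 2500 nM and 15000 nM.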

Compound 4, half-maximal inhibitory concentration: 30200 nM
For compound 4 the middle estimate is 5.0-fold (0.70 log units) below the measured one, outside the stated range (above it).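

In this assay the same change of methyl in place of hydrogen, now four bonds along the chain from an aromatic carbon, brings a 2.8-fold higher number from compound 3 to compound 4 (0.45 log units; beyond the scatter). Set side by side, the two steps show that this change does not carry over unchanged from one core to another in this series: the same change on two cores in this assay, an at least 1.9-fold lower number (0.28 log units; that floor lies within the scatter) from compound 1 to compound 2 and a 2.8-fold higher number (0.45 log units; beyond the scatter) from compound 3 to compound 4, at least 5.4-fold (0.73 log units) apart, beyond the scatter of two such steps. They do not show whether the core or the place of the methyl sets that gap, for the methyl enters two bonds along the chain from an aromatic carbon in the earlier step and four bonds along the chain in the new one, and the earlier step starts from a value that is only a limit: the limit of > 100000 nM in this assay, at which 1 of the 4 values shown sits.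

The compounds shown leave open how the same chains would read on a single core, for instance the butyl chain of compound 3 and the longer chain of compound 4 carried on the core of compound 1, which has no trifluoromethyl group. They also leave open whether a still longer chain, or an amine or a carboxylic acid at the end of the chain, would raise the number further or bring it down again.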